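Adding a Methyl Group: Expected Antiproliferative Shift

The source may report more compounds than this note shows. Statements on the series, on what has been measured and on what is new or still open speak of the compounds shown alone.

Three compounds sharing one core were tested in a functional assay on KB cells (Homo sapiens) for antiproliferative activity, read by sulforhodamine B assay, with a stated time of 3 days; a higher number here means that more compound is needed for the effect, a lower number that less compound is needed. Compound 1 `CCC1=C(O)c2c(oc(-c3cccc(F)c3)cc2=O)C(CC)(CC)C1=O` carries a 3-fluorophenyl group, and in this assay compound 1 reaches only a limit, > 56.2 uM. Compound 2 `CCC1=C(O)c2c(oc(-c3ccc(C)c(F)c3)cc2=O)C(CC)(CC)C1=O` differs from it by methyl in place of hydrogen on an aromatic carbon, and the step is an at least 2.0-fold lower number from compound 1 to compound 2 (0.30 log units; that floor lies within the scatter), a floor set by the limit of > 56.2 uM in this assay, at which 1 of the 3 values shown sits. Compound 3 `CCC1=C(O)c2c(oc(-c3ccc(OC)c(C)c3)cc2=O)C(CC)(CC)C1=O` differs from compound 1 by 4-methoxy-3-methylphenyl in place of 3-fluorophenyl on an aromatic carbon; in this assay compound 3 gives 28.5 uM, while compound 2 gives 28.1 uM, and the step of a 1.0-fold higher number from compound 2 to compound 3 (0.01 log units; within the scatter) lies within the scatter.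

Compound 4 `CCC1=C(O)c2c(oc(-c3ccc(OC)c(C)c3C)cc2=O)C(CC)(CC)C1=O` has not yet been measured. It differs from compound 3 by methyl in place of hydrogen on an aromatic carbon, the same kind of change as that from compound 1 to compound 2, though the surroundings differ: there the methyl entered ortho to a fluoro group and para to a large group, here it enters ortho to a large group, ortho to a methyl group and meta to a methoxy group. The expectation rests on the earlier step of an at least 2.0-fold lower number from compound 1 to compound 2 (0.30 log units; that floor lies within the scatter). For compound 4 the expected step is a 1.4-fold lower number from compound 3 to compound 4 (0.15 log units; within the scatter). The estimate for compound 4 in this assay is 20 uM, expected to lie between 8 uM and 50 uM.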

Compound 4, concentration for half-maximal effect: 5.43 uM
For compound 4 the middle estimate is 3.7-fold (0.57 log units) above the measured one; measured number outside the range, below it.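

In this assay, methyl in place of hydrogen on an aromatic carbon gives a 5.2-fold lower number from compound 3 to compound 4 (0.72 log units; beyond the scatter), here with the new methyl ortho to a large group, ortho to a methyl group and meta to a methoxy group. Set beside the earlier case, this shows the same change pointing the same way on two cores, but two pairs do not establish a general rule for the series, and the size of the effect cannot be said to carry over: the same change on two cores in this assay, an at least 2.0-fold lower number (0.30 log units; that floor lies within the scatter) from compound 1 to compound 2 and a 5.2-fold lower number (0.72 log units; beyond the scatter) from compound 3 to compound 4; the limit leaves it open whether they differ The earlier step rests on compound 1, whose reading is a limit and not a number: the limit of > 56.2 uM in this assay, at which 1 of the 4 values shown sits.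

The compounds shown leave open whether chloro, an amine or a carboxylic acid in place of this new methyl would give a step of similar size. They also leave open whether the methyl would behave alike on an aromatic ring that carries no methoxy group.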